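The source may hold more compounds than are shown below. What is called first, only, known or untested is meant among the compounds shown, and "the series" means these compounds.

Measured in a functional assay on HepG2 cells (Homo sapiens) for cytotoxicity, read by MTT assay, with a stated time of 24 h; on this read-out higher numbers stand for weaker inhibition and lower numbers for stronger inhibition:
compound 1 `O=C1/C(=C/c2ccncc2)CN(S(=O)(=O)c2ccc(C(F)(F)F)cc2)C/C1=C\c1ccccc1F`: 4030 nM
compound 2 `O=C1/C(=C/c2ccncc2)CN(S(=O)(=O)c2ccc(F)cc2)C/C1=C\c1ccccc1F`: 20300 nM

In this assay, within the data shown here, compound 2 stands at 20300 nM, the higher of the two numbers so far, with compound 1 lying below it by more than the scatter. Compound 3 `CC(=O)Nc1ccc(S(=O)(=O)N2C/C(=C\c3ccncc3)C(=O)/C(=C/c3ccccc3F)C2)cc1` has not yet been measured. It keeps the shared core of compound 2 and changes one group: acetamido in place of fluoro on an aromatic carbon. This is acetamido in place of fluoro on an aromatic carbon, para to a large group, turning 4-fluorophenyl into 4-acetamidophenyl.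

Among the measured compounds shown here, only one measured step bears on this carbon: a 5.0-fold higher number from compound 1 to compound 2 (0.70 log units; beyond the scatter). That step, fluoro in place of trifluoromethyl, is modest but beyond the scatter. It shows that a change here has moved the number once, yet neither measured compound carries acetamido, so the direction remains uncertain. Going by compound 1 at 4030 nM, a modest move to a lower number seems somewhat likelier than a rise. The expected step is a 1.8-fold lower number from compound 2 to compound 3 (0.27 log units; within the scatter), though no change beyond the scatter would not surprise. For compound 3 the estimate is 11000 nM, with an expected range from 3500 nM to 30000 nM.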

Compound 3, half-maximal inhibitory concentration: 11700 nM
For compound 3 the middle estimate is 1.1-fold (0.03 log units) below the measured one; measured number inside the range.
By their numbers in this assay, from the lowest: compound 1; then compounds 3 and 2 (each within the scatter of the next).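

In this assay, acetamido in place of fluoro on this aromatic carbon gives a 1.7-fold lower number from compound 2 to compound 3 (0.24 log units; within the scatter) and so does not separate the two groups, even though acetamido brings a hydrogen-bond donor and a hydrogen-bond acceptor that fluoro lacks. Acetamido in place of trifluoromethyl gives a 2.9-fold higher number from compound 1 to compound 3 (0.46 log units; beyond the scatter) and shows that compound 1, the trifluoromethyl member, stands apart from the acetamido compound as well as from the fluoro compound, so among these three groups only trifluoromethyl gives a number set apart from the others. Nothing measured here explains why the three groups fall this way.

Going by these compounds, the three compounds cover only fluoro, trifluoromethyl and acetamido at this carbon, so it remains open where groups such as an amine, a carboxylic acid, a methoxy or a longer chain would fall, and whether any of them would match or pass the number of compound 1. On these data alone, it is also open whether the same order of these groups would hold if the 2-fluorophenyl or pyridine-bearing arms of the shared core were changed.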